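Replacing a Sulfonamide Linker with a Reversed Amide Chain

A few compounds are considered here, and "the series" means these few. Any claim that something is new, unique, unknown or untested is made for them only; others in the source may bear on it.

Compound 1, `CN(C)C(=O)c1cc2cnc(Nc3ccc(S(=O)(=O)NCCCCN=C=S)cc3)nc2n1C1CCCC1`, was tested in a functional assay on NCI-H1299 cells (Homo sapiens) for inhibition, read by CCK-8 assay, with a stated time of 72 h, tested at 10 uM (on this read-out lower numbers stand for a weaker effect and higher numbers for a stronger effect at the one concentration tested), where it gives 72.7%. Among the three compounds measured so far it has the lowest number, but its gaps to the others lie within the usual scatter: compound 2, `CN(C)C(=O)c1cc2cnc(Nc3ccc(C(=O)NCCCCN=C=S)cc3F)nc2n1C1CCCC1`, gives 78.9%, and compound 3, `CN(C)C(=O)c1cc2cnc(Nc3ccc(C(=O)NCCCCCCN=C=S)cc3F)nc2n1C1CCCC1`, gives 77.6%.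

Compound 4, `CN(C)C(=O)c1cc2cnc(Nc3ccc(NC(=O)CCCCCCN=C=S)cc3)nc2n1C1CCCC1`, has not yet been measured. It differs from compound 1 at one place: a group of 12 heavy atoms (8 carbon, 2 nitrogen, 1 oxygen, 1 sulfur; no ring) in place of a group of 11 heavy atoms (5 carbon, 2 nitrogen, 2 oxygen, 2 sulfur; no ring), on an aromatic carbon. The group that leaves carries a sulfonamide and an isothiocyanate on a chain; the group that enters is an amide chain ending in the same isothiocyanate, attached through its nitrogen to the aromatic ring, para to a large group.

Going by the values given here, only one measured step is a single change, a number 1.3 percentage points lower from compound 2 to compound 3 (within the scatter), and it shows that lengthening the chain before the isothiocyanate leaves the read-out within the scatter. Among the compounds with values here, no measured step changes the linker type as this one does; compounds 1 and 2 differ in two places, so their values can only be read side by side, and they sit close together.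

Given this, the step of a number 2.3 percentage points higher from compound 1 to compound 4 (within the scatter) is expected to stay within the scatter, and compound 4 is estimated at 75%, between 60% and 88%.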

Compound 4, a percentage reported as inhibition, at one concentration (the size of the read-out at that concentration, not a potency): 80.9%
Estimate against measurement, compound 4: 5.9 percentage points below; low and high end bracket the measured number.
By their numbers in this assay, from the lowest: compounds 1, 3, 2 and 4 (each within the scatter of the next).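

In this assay, a number 8.2 percentage points higher from compound 1 to compound 4 (within the scatter) is the only single-place step shown that changes the linker type, not just the chain length. At this aromatic carbon, the sulfonamide chain can therefore give way to an amide chain attached through its nitrogen and ending in the same isothiocyanate, with the read-out staying within its usual scatter. No separate measurement shows what the exchange does to the molecule or why the read-out holds up across it.

Still open, as far as these compounds go, is whether the isothiocyanate itself is needed, which a compound carrying a primary amine at the end of the same amide chain would test directly, and whether a shorter chain on this nitrogen-linked amide would behave like the longer one. Because each compound was read at a single concentration, the numbers also leave open whether compound 1 and compound 4 would differ in potency across a full range of concentrations.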